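A few compounds are considered here, and "the series" means these few. Any claim that something is new, unique, unknown or untested is made for them only; others in the source may bear on it.

Measured so far:
- compound 1 `O=C(NCCCN1CCN(c2ccccn2)CC1)c1cccc2ccccc12`: > 10000 nM in an assay on HEK293 cells for inhibition of sodium-dependent dopamine transporter (Homo sapiens), read by scintillation counting; a higher number here means a weaker inhibitor, a lower number a stronger inhibitor
- compound 2 `O=C(NCCCN1CCN(c2ccccn2)CC1)c1ccc2ccccc2n1`: > 10000 nM in this assay

Both values are limits of the assay, not numbers. For compound 1 the value > 10000 nM is a limit. For compound 2 the value > 10000 nM is likewise a limit. Among the measured compounds shown here, compound 2 therefore stands at the same place as compound 1 on the numbers so far, namely (the limit of > 10000 nM in this assay, at which 2 of the 2 values shown sit), and no step between measured compounds can be sized here.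

Compound 3 `O=C(NCCCN1CCN(c2ncccn2)CC1)c1ccc2ccccc2n1` is not yet measured. It differs from compound 2 by pyrimidin-2-yl in place of pyridin-2-yl on an amine nitrogen in a ring. With both measured values sitting at the limit, no direction for this change can be read from the series; the step from compound 2 to compound 3 is expected to be none beyond the scatter, with a new limit the most likely outcome. Compound 3 is therefore estimated at 20000 nM in this assay, between 5000 nM and 80000 nM, which corresponds to an expected step that the limit leaves unreadable from compound 2 to compound 3.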

Compound 3, half-maximal inhibitory concentration: > 10000 nM
Compound 3: no number, only a limit (the forecaster's own chance of this, stated with the estimate: 85%); the middle value lies beyond the limit too.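

In this assay compound 3 gives > 10000 nM, a limit and not a number. No step can be read between compound 2 and compound 3, as all values shown sit at one place: the limit of > 10000 nM in this assay, at which 3 of the 3 values shown sit.

The compounds shown leave open which change to the shared core, if any, would give a measurable value.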